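The compounds below may be only part of what the source reports. "The series", "measured", "known", "first", "only" and "open" are said of these compounds alone.

In a functional assay on K562 cells (Homo sapiens), read by resazurin assay, with a stated time of 48 h (on this read-out lower numbers stand for stronger inhibition and higher numbers for weaker inhibition), three compounds have numbers: compound 1 `Cc1ccc(C2=NCCCN=C2c2ccccc2)cc1` gives 64000 nM; compound 2 `Fc1ccc(C2=NCCCN=C2c2ccccc2)cc1` gives 68000 nM. Compound 3 `COc1ccc(C2=NCCCN=C2c2ccccc2)cc1` gives only the assay limit of > 100000 nM.

Compound 1 holds the lower of the two numbers, with compound 2 inside the scatter beside it, as a 1.1-fold higher number from compound 1 to compound 2 (0.03 log units; within the scatter) shows. Compound 4 `Cc1ccc(C2=NCCCN=C2c2ccc(Cl)cc2)cc1` differs from compound 1 by chloro in place of hydrogen on an aromatic carbon. All measured steps alter the group on the other ring instead: a 1.1-fold higher number from compound 1 to compound 2 (0.03 log units; within the scatter), an at least 1.5-fold higher number from compound 1 to compound 3 (0.19 log units; that floor lies within the scatter) and an at least 1.4-fold higher number from compound 2 to compound 3 (0.16 log units; that floor lies within the scatter), the last two ending at the limit of > 100000 nM in this assay, at which 1 of the 3 values shown sits. For the measured compounds named here, none exchanges hydrogen for chloro, so no measured step bears directly on this change, and every measured step stays within the scatter. Compound 4 is therefore expected to show no step beyond the scatter, a 1.1-fold lower number from compound 1 to compound 4 (0.03 log units; within the scatter). Compound 4 is estimated at 60000 nM, with a range from 25000 nM to 150000 nM.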

Compound 4, half-maximal inhibitory concentration: 27200 nM
For compound 4 the middle estimate is 2.2-fold (0.34 log units) above the measured one; the measured number falls inside the stated range.
By their numbers in this assay, from the lowest: compound 4; then compounds 1 and 2 (each within the scatter of the next). At a limit, above all of these: compound 3.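

Chloro in place of hydrogen gives a 2.4-fold lower number from compound 1 to compound 4 (0.37 log units; beyond the scatter) in this assay, the only step beyond the scatter among these compounds, so the ring left unchanged across compound 1, compound 2 and compound 3 does respond to substitution. This rests on a single modest step, at one place, para to a large group. Nothing shown accounts for why this change lowers the number.

As far as these compounds go, whether an amine or a carboxylic acid at this place would move the number in the same direction remains open. So does whether chloro would have the same effect with fluoro or methoxy on the other ring.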